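A few compounds are considered here, and "the series" means these few. Any claim that something is new, unique, unknown or untested is made for them only; others in the source may bear on it.

Within the data shown here, compound 2 `CCN(CC)CCNc1nc(-c2ccc(NC(=O)Nc3ccc(Cl)cc3)cc2)nc2ccsc12` gives the lower of the two numbers measured so far: in a functional assay on NCI-H460 cells (Homo sapiens) for cytotoxicity, read by MTT assay, with a stated time of 72 h (on this read-out higher numbers stand for weaker inhibition and lower numbers for stronger inhibition), compound 2 gives 190 nM, while compound 1 `CN(C)CCCNc1nc(-c2ccc(NC(=O)Nc3ccc(Cl)cc3Cl)cc2)nc2ccsc12` gives 1020 nM in this assay, a gap beyond the usual scatter. Among the measured compounds shown here, compound 1 differs from compound 2 in two places at once, so the two values show only that the pair sits apart, not which difference is responsible. Compound 3 `CCN(CC)CCNc1nc(-c2ccc(NC(=O)Nc3ccc(Cl)cc3Cl)cc2)nc2ccsc12` changes one place only: chloro in place of hydrogen on an aromatic carbon. Compound 3 therefore carries the same 2,4-dichlorophenyl as compound 1 but keeps the diethylaminoethyl chain of compound 2. For the measured compounds named here, nothing measured isolates this single change, so the expectation is uncertain; since the only compound with the 2,4-dichlorophenyl, compound 1, gives 1020 nM, a modest weakening is expected, about a 2.1-fold higher number from compound 2 to compound 3 (0.32 log units; beyond the scatter). For compound 3 the expected value in this assay is 400 nM, within a range from 120 nM to 1300 nM.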

Compound 3, half-maximal inhibitory concentration: 1890 nM
Estimate against measurement, compound 3: 4.7-fold (0.67 log units) below; the whole stated range lies below it.
By their numbers in this assay, from the lowest: compound 2; then compounds 1 and 3 (each within the scatter of the next).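

Adding a chloro to the 4-chlorophenyl to give the 2,4-dichlorophenyl, on the aromatic carbon ortho to a large group, clearly weakens the effect in this assay (a 9.9-fold higher number from compound 2 to compound 3 (1.00 log units; beyond the scatter)). This is the first change shown that isolates this position, and it reveals that one added chlorine atom there is enough for a large loss. With the 2,4-dichlorophenyl held fixed, swapping the amine chain gives a 1.9-fold higher number from compound 1 to compound 3 (0.27 log units; within the scatter) and so does not separate the two chains, which places the gap between compound 1 and compound 2 mainly with the added chloro.

Nothing shown explains why this single chloro has so large an effect. As far as these compounds go, whether a fluoro, a methyl or a methoxy at the same place would cost as much remains open.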